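The compounds below may be only part of what the source reports. "The series", "measured", "known", "first", "only" and "open" are said of these compounds alone.

Measured so far:
- compound 1 `FC(F)(F)c1ccccc1Nc1nc2nonc2nc1Nc1ccccc1C(F)(F)F`: in an assay on mitochondria from L6 cells (Rattus norvegicus) for activation, with a stated time of 90 min (on this read-out higher numbers stand for an effect only at larger amounts of compound and lower numbers for an effect already at smaller amounts), compound 1 gives 1000 nM
- compound 2 `Fc1ccccc1Nc1nc2nonc2nc1Nc1cccc(F)c1F`: in this assay compound 2 gives 500 nM

Compound 2 holds the lower of the two numbers, but its gap to compound 1 lies within the scatter, so the two cannot be told apart on these data.

Compound 3 `CCOc1cccc(Nc2nc3nonc3nc2Nc2ccccc2F)c1` differs from compound 2 by 3-ethoxyphenyl in place of 2,3-difluorophenyl on a nitrogen on an aromatic ring. Among the measured compounds shown here, no step between measured compounds bears on this change, so the expected step is a 1.2-fold higher number from compound 2 to compound 3 (0.08 log units; within the scatter), not beyond the scatter in either direction. Compound 3 is therefore expected near 600 nM, with a range of 200 nM to 2000 nM.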

Compound 3, half-maximal effective concentration: 2200 nM
Estimate against measurement, compound 3: 3.7-fold (0.56 log units) below; the measured number lies above the stated range.
By their numbers in this assay, from the lowest: compounds 2 and 1 (each within the scatter of the next); then compound 3.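

In this assay the place on a nitrogen on an aromatic ring is not indifferent to its group: 3-ethoxyphenyl in place of 2,3-difluorophenyl gives a 4.4-fold higher number from compound 2 to compound 3 (0.64 log units; beyond the scatter) and so a difference beyond the scatter, which compound 1 and compound 2 did not show. This single change removes both fluorines and brings in an oxygen and a hydrogen-bond acceptor, so the step cannot be assigned to any one of these. No evidence on the reason for the step is available. Going by these compounds, whether the oxygen or the missing fluorines carry the step stays open, as does the result for a phenyl carrying an amine or a carboxylic acid at this place.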